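Swapping piperidine for methylpiperazine on a second core

The source may hold more compounds than are shown below. What is called first, only, known or untested is meant among the compounds shown, and "the series" means these compounds.

Compound 1 `COc1cc(OC)c2c(N3CCCCC3)nc(-c3ccc(C(=O)NO)cc3)nc2c1` carries a piperidin-1-yl group on its shared core. In an assay on isolated protein for inhibition of protein deacetylase HDAC6 (Homo sapiens), tested at 0.5 uM (on this read-out lower numbers stand for less inhibition and higher numbers for more inhibition at the one concentration tested (going by the name of the read-out)), compound 1 gives 62.5%. Compound 2 `COc1cc(OC)c2c(N3CCN(C)CC3)nc(-c3ccc(C(=O)NO)cc3)nc2c1` differs from it by 4-methylpiperazin-1-yl in place of piperidin-1-yl on an aromatic carbon, and in this assay compound 2 gives 78.3%. That change made a number 15.8 percentage points higher from compound 1 to compound 2 (beyond the scatter). Compound 3 `O=C(NO)c1ccc(-c2nc(N3CCCCC3)c3ccc(Cl)cc3n2)cc1` rests on a different core; the difference between the two cores is not broken down here. In this assay compound 3 gives 59.6%, which sits within the scatter of compound 1 and beyond the scatter from compound 2.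

Compound 4 `CN1CCN(c2nc(-c3ccc(C(=O)NO)cc3)nc3cc(Cl)ccc23)CC1` has not been measured. It differs from compound 3 by 4-methylpiperazin-1-yl in place of piperidin-1-yl on an aromatic carbon. This is the same kind of change as between compound 1 and compound 2, though the surroundings read differently: in compound 1 the place is meta to a 4-(hydroxycarbamoyl)phenyl group, in compound 3 meta to a large group. The expectation rests on compound 1 and compound 2, where the same kind of change gave a number 15.8 percentage points higher from compound 1 to compound 2 (beyond the scatter). A step of a number 15.4 percentage points higher from compound 3 to compound 4 (beyond the scatter) is therefore expected. Compound 4 is estimated at 75%, expected to fall between 62% and 86%.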

Compound 4, a percentage reported as inhibition, at one concentration (the size of the read-out at that concentration, not a potency): 94.4%
For compound 4 the middle estimate is 19.4 percentage points below the measured one; measured number outside the range, above it.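

In this assay, putting 4-methylpiperazin-1-yl in place of piperidin-1-yl on the second core gave a number 34.8 percentage points higher from compound 3 to compound 4 (beyond the scatter). The direction of the change carried over from one core to the other, but its size did not stay the same: the same change on two cores in this assay, a number 15.8 percentage points higher (beyond the scatter) from compound 1 to compound 2 and a number 34.8 percentage points higher (beyond the scatter) from compound 3 to compound 4, 19 percentage points apart, beyond the scatter of two such steps With only these two pairs, the result shows that a step measured on one core in this series cannot simply be copied to another as a fixed amount; it does not show which feature of the two cores goes with the larger step, nor what size the step would take on a third core.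

The compounds shown leave open whether another cyclic amine in the same place, such as morpholine or 4-ethylpiperazin-1-yl, would follow the same direction on both cores. On these data alone, it also remains open how the two 4-methylpiperazin-1-yl compounds would compare across a range of concentrations, since each number here comes from a single concentration.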